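Nitroimidazole Styryl Analogues: Macrophage Cytotoxicity and a Dimethylamino Variant

The source may report more compounds than this note shows. Statements on the series, on what has been measured and on what is new or still open speak of the compounds shown alone.

The measured compounds:
compound 1 `COc1ccc(/C=C/c2ncc([N+](=O)[O-])n2CC(C)O)cc1` with 560 nM
compound 2 `CC(O)Cn1c([N+](=O)[O-])cnc1/C=C/c1cccc(Br)c1` with 620 nM
compound 3 `CC(O)Cn1c([N+](=O)[O-])cnc1/C=C/c1ccc(Cl)cc1Cl` with 810 nM

Three compounds sharing one core were tested in an ADME assay on cells (Macrophage, Homo sapiens) for cytotoxicity, read by MTT assay, with a stated time of 24 h; on this read-out higher numbers stand for lower toxicity in this test and lower numbers for higher toxicity in this test. Compound 1 gives 560 nM, compound 2 gives 620 nM and compound 3 gives 810 nM. Among the compounds with values here, compound 1 returns the smallest of the three numbers, yet its gaps to compound 2 and to compound 3 both lie within the usual scatter of this assay, so the three readings cannot be told apart and no compound can be called more or less toxic than another on this evidence.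

Compound 4 `CC(O)Cn1c([N+](=O)[O-])cnc1/C=C/c1ccc(N(C)C)cc1` has not been measured. It differs from compound 1 in one place: dimethylamino in place of methoxy on an aromatic carbon. Within the data shown here, no step between measured compounds is available for this change, and the three measured values all sit close together whatever the aryl substituent. The expectation for this assay is therefore a step no larger than the scatter, with no clear direction, so that the estimated step of a 1.1-fold higher number from compound 1 to compound 4 (0.04 log units; within the scatter) stays small. Compound 4 is expected to give about 620 nM, with a likely range from 300 nM to 1300 nM.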

Compound 4, half-maximal cytotoxic concentration: 680 nM
Estimate against measurement, compound 4: 1.1-fold (0.04 log units) below; the measured number falls inside the stated range.
By their numbers in this assay, from the lowest: compounds 1, 2, 4 and 3 (each within the scatter of the next).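

In this assay, within the data shown here, the exchange of methoxy for dimethylamino on an aromatic carbon, para to a large group, gives a 1.2-fold higher number from compound 1 to compound 4 (0.08 log units; within the scatter), and this is the first comparison in which only one place differs. Among these compounds, the earlier compounds could show only that their readings lay close together while their aryl groups differed in more than one respect; this pair shows the same closeness for a single, defined exchange at this position, so the assay does not separate methoxy from dimethylamino here. No measurement of any property of these two groups bears on this result, and the pair offers no explanation of it.

All the compounds shown carry uncharged substituents on the aromatic ring, so it remains open whether a carboxylic acid or a primary amine at this same place would also stay within the scatter of compound 1. All of them also keep the nitro group on the shared core, which leaves open whether replacing it with a nitrile would change the reading in this macrophage test.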